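A weak pair and a nitro-bearing analogue awaiting measurement

The source may report more compounds than this note shows. Statements on the series, on what has been measured and on what is new or still open speak of the compounds shown alone.

In a functional assay on HepG2 cells (Homo sapiens) for antiproliferative activity, read by MTT assay, with a stated time of 48 h (a higher number here means a weaker inhibitor, a lower number a stronger inhibitor), compound 1 `N#CC1=C(N)Oc2c(c3nc4ccccc4nc3c3ccccc23)C12C(=O)N(Cc1cnnn1-c1ccc(F)cc1)c1ccccc12` reports only the assay limit, > 50000 nM. Within the data shown here, compound 2 `N#CC1=C(N)Oc2c(N)cc3nc4ccccc4nc3c2C12C(=O)N(Cc1cnnn1-c1ccccc1Br)c1ccccc12` is the only compound with a measured number in this assay, where it gives 38000 nM. The other value shown is a limit, (the limit of > 50000 nM in this assay, at which 1 of the 2 values shown sits). Among the measured compounds shown here, with a single number and a limit, no step between measured compounds can be drawn, and the two values show only that both compounds are weak inhibitors in this assay.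

Compound 3 `N#CC1=C(N)Oc2c(N)cc3nc4ccccc4nc3c2C12C(=O)N(Cc1cnnn1-c1ccc(Cl)cc1[N+](=O)[O-])c1ccccc12` differs from compound 2 in one place: 4-chloro-2-nitrophenyl in place of 2-bromophenyl on an aromatic nitrogen. Compound 1 offers only a limit in this assay. The expectation for compound 3 therefore rests on compound 2 alone. The exchange of one substituted phenyl ring for another on the same aromatic nitrogen gives no ground for expecting a step beyond the usual scatter, so the expected step is a 1.1-fold lower number from compound 2 to compound 3 (0.04 log units; within the scatter), small and in no clear direction. Compound 3 is therefore estimated at 35000 nM in this assay, with a range from 15000 nM to 80000 nM, and with a real chance that only a limit is reported.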

Compound 3, half-maximal inhibitory concentration: > 50000 nM
Compound 3: only a limit was reported; the forecaster's own chance of this, stated with the estimate: 30%; at least 1.4-fold (0.15 log units) between middle value and limit.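

In this assay, 4-chloro-2-nitrophenyl in place of 2-bromophenyl on an aromatic nitrogen gives an at least 1.3-fold higher number from compound 2 to compound 3 (0.11 log units; that floor lies within the scatter). Compound 3 gives > 50000 nM, which is a limit and not a number, so the step has a floor but no known size, and that floor does not separate the two compounds beyond the usual scatter. This pair is the first one-place comparison at this position, and it gives no sign that the larger ring substituents of compound 3 lower the number, while the assay limit now holds for most of the compounds shown: the limit of > 50000 nM in this assay, at which 2 of the 3 values shown sit.

With only one measured number in this assay, the compounds shown leave open whether any change at this position can bring a clearly lower number than that of compound 2. An amine or a carboxylic acid on this phenyl ring, or a longer chain in place of the ring on the same aromatic nitrogen, remains an open case, and so does the question of whether the shared core itself sets the weak level seen here.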